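This account rests on a few compounds, and the source may have more. Where it says the series, first, only, none or still open, it means among the compounds named here.

In a toxicity assay on A549 cells (Homo sapiens) for cytotoxicity, read by luminescence and CellTiter-Glo, with a stated time of 48 h (a lower number here means that less compound is tolerated, a higher number that more compound is tolerated), compound 1 (`CCCCOc1ccc(-c2nc3ncccn3c2NCc2ccc3ccccc3c2)cc1`) gives 33000 nM as its half-maximal cytotoxic concentration. Compound 2 (`CCNC(=O)CCCOc1ccc(-c2nc3ncccn3c2NC2CCCCC2)cc1`) gives > 100000 nM here, which is a limit and not a number. For the measured compounds named here, of the two values so far, one sits at that limit (the limit of > 100000 nM in this assay, at which 1 of the 2 values shown sits), so compound 2 has no exact place on the scale. Compound 3 (`COCCOc1ccc(-c2nc3ncccn3c2NC2CCCCC2)cc1`) differs from compound 2 in one place (methoxy in place of (ethylcarbamoyl)methyl on a saturated chain carbon, two bonds along the chain from an oxygen on an aromatic ring): methoxy in place of (ethylcarbamoyl)methyl, on a saturated chain carbon, two bonds along the chain from an oxygen on an aromatic ring. Going by the values given here, no measured pair shows this change. The expectation rests on compound 2 with > 100000 nM as its limit, and the rest of the molecule stays the same. A small step toward a lower number is expected (an at least 1.4-fold lower number from compound 2 to compound 3 (0.15 log units; that floor lies within the scatter)) in this assay, perhaps none beyond the scatter. For compound 3 the expected value is 70000 nM with 30000 nM to 100000 nM as the estimated range.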

Compound 3, half-maximal cytotoxic concentration: > 100000 nM
Compound 3: only a limit was reported; the forecaster's own chance of this, stated with the estimate: 60%; middle value at least 1.4-fold (0.15 log units) away from the limit.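

For the compounds shown here, compound 2 and compound 3 each give only a limit in this assay, not a number, and no step between them can be read. On these data alone, whether methoxy in place of (ethylcarbamoyl)methyl changes the half-maximal cytotoxic concentration at all, and in which direction, remains open.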